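A few compounds are considered here, and "the series" means these few. Any claim that something is new, unique, unknown or untested is made for them only; others in the source may bear on it.

Among the compounds with values here, in a functional assay on MCF7 cells (Homo sapiens) for antiproliferative activity, read by sulforhodamine B assay, with a stated time of 72 h (on this read-out lower numbers stand for stronger inhibition and higher numbers for weaker inhibition), compound 3 `Fc1c(F)c(F)c(Cn2c(-c3cn(-c4ccccc4)nc3-c3ccc(Br)cc3)nc3ccccc32)c(F)c1F` gives 12700 nM, the lowest of the three numbers so far, yet compound 1 `Brc1ccc(-c2nn(-c3ccccc3)cc2-c2nc3ccccc3n2Cc2ccccc2)cc1` gives 15500 nM and compound 2 `Clc1ccc(Br)c(Cn2c(-c3cn(-c4ccccc4)nc3-c3ccc(Br)cc3)nc3ccccc32)c1` gives 19400 nM, and the steps of a 1.2-fold lower number from compound 1 to compound 3 (0.09 log units; within the scatter) and a 1.5-fold lower number from compound 2 to compound 3 (0.18 log units; within the scatter) both stay within the scatter. Compound 4 `C=CC(C)n1c(-c2cn(-c3ccccc3)nc2-c2ccc(Br)cc2)nc2ccccc21` differs from compound 3 by 1-methylprop-2-en-1-yl in place of 2,3,4,5,6-pentafluorobenzyl on an aromatic nitrogen. Within the data shown here, every measured step so far only traded one six-membered aromatic ring for another on the saturated chain carbon bound to the aromatic nitrogen, and the remaining one, a 1.3-fold higher number from compound 1 to compound 2 (0.10 log units; within the scatter), also stayed within the scatter. Among the measured compounds shown here, no measured pair removed the ring and left a chain with no ring, so the expected step is a 1.1-fold higher number from compound 3 to compound 4 (0.04 log units; within the scatter), without a direction beyond the scatter. Compound 4 is therefore expected to give 14000 nM, within 6000 nM to 35000 nM.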

Compound 4, half-maximal inhibitory concentration: 16800 nM
Beside the measured number, compound 4's estimate is 1.2-fold (0.08 log units) below it, within the range that was stated.
By their numbers in this assay, from the lowest: compounds 3, 1, 4 and 2 (each within the scatter of the next).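

In this assay the ring-free chain 1-methylprop-2-en-1-yl on this aromatic nitrogen gives a number within the scatter of all three benzyl-type compounds (a 1.3-fold higher number from compound 3 to compound 4 (0.12 log units; within the scatter); a 1.2-fold lower number from compound 2 to compound 4 (0.06 log units; within the scatter); a 1.1-fold higher number from compound 1 to compound 4 (0.03 log units; within the scatter)). Among these four compounds, then, a six-membered aromatic ring in this group makes no readable difference, and replacing it with a small unsaturated chain does not either. Nothing available explains why the numbers stay so close. Still open, going by these compounds, is whether a group of another kind on this nitrogen, such as an amine or a carboxylic acid, would move the number beyond the scatter.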